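The compounds below may be only part of what the source reports. "The series", "measured", "known", "first", "only" and "open" are said of these compounds alone.

Measured compounds:
compound 1, `CN(C)CCCOc1ccccc1/C=C/c1ccccc1`: 14.2%
compound 2, `CN(C)CCCCOc1ccccc1/C=C/c1ccc(Cl)cc1`: 0%
compound 3, `CN(C)CCCCOc1ccc(/C=C/c2ccccc2)cc1`: 12.5%

All three have been run in a functional assay on the whole organism with Mus musculus as the target, in the maximal electroshock model, at a dose of 50 mg/kg by the oral route; a higher number here means more inhibition at the dose given (going by the name of the read-out), a lower number less inhibition. Compound 1 gives the highest number of the three, 14.2%. Compound 3 gives 12.5%, which lies within the scatter of compound 1, so the two cannot be told apart. Compound 2 gives 0%, a number that lies beyond the scatter below compound 1. Among the measured compounds shown here, no pair of the measured compounds differs in one place only, so no step of this assay can be read from them, and nothing is known of how a change at the basic end of the chain moves the read-out.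

Compound 4, `CCN1CCN(CCCCOc2ccccc2/C=C/c2ccccc2)CC1`, has not yet been measured. It stands against compound 1 by the following change: (4-ethylpiperazin-1-yl)methyl in place of dimethylamino on a saturated chain carbon, three bonds along the chain from an oxygen on an aromatic ring. For the measured compounds named here, the numbers seen so far are all low, and no measured pair supports a step of any particular size or direction for this kind of change. The step in this assay from compound 1 to compound 4 is therefore expected to be a number 0.8 percentage points higher from compound 1 to compound 4 (within the scatter), not beyond the scatter. Compound 4 is expected to give about 15%, with a range from 0% to 40%.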

Compound 4, a percentage reported as inhibition, in the whole organism at one dose (the size of the read-out at that dose, not a potency): 33.3%
Estimate against measurement, compound 4: 18.3 percentage points below, and the stated range covers the measured number.
By their numbers in this assay, from the lowest: compound 2; then compounds 3 and 1 (each within the scatter of the next); then compound 4.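

In this assay, among the compounds shown here, (4-ethylpiperazin-1-yl)methyl in place of dimethylamino on a saturated chain carbon, three bonds along the chain from an oxygen on an aromatic ring, gives a number 19.1 percentage points higher from compound 1 to compound 4 (beyond the scatter), the first step that can be read. This place therefore accepts a larger group carrying a six-membered non-aromatic ring with 2 hetero atoms, and the read-out rises rather than being lost. Nothing measured accounts for the rise.

The change brings in the ring, the second nitrogen and the ethyl together, so piperidin-1-ylmethyl, morpholin-4-ylmethyl or (4-methylpiperazin-1-yl)methyl at the same place would be needed to tell which part matters. From the compounds shown here alone, whether the same change gives a similar step on the core of compound 2 or compound 3 also remains open.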